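Fluoro for Chloro on a Bicyclic Pyridine Agonist

This account rests on a few compounds, and the source may have more. Where it says the series, first, only, none or still open, it means among the compounds named here.

Measured compounds:
compound 1 `COc1cncc(C2=CC3CC(C2)CN(C)C3)c1` — 15%
compound 2 `CN1C[C@H]2C=C(c3cccnc3)C[C@H](C2)C1` — 11%
compound 3 `Clc1ccc(C2=CC3CNCC(C2)C3)cn1` — 152%

Three compounds were tested in an in vitro functional assay on SH-EP1 cells for agonist activity at Neuronal acetylcholine receptor; alpha4/beta2 (Homo sapiens), read by FLIPR and calcium flux; a lower number here means a smaller maximal response, a higher number a larger maximal response. Compound 1 and compound 2 sit close together at the low end, within the scatter of each other. Compound 3 stands highest of the three; in this assay compound 3 reaches 152%, far above both others, beyond the scatter in each case.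

Compound 4 `Fc1ccc(C2=CC3CNCC(C2)C3)cn1` has not yet been measured. It differs from compound 3 in a single place: fluoro in place of chloro on an aromatic carbon. For the measured compounds named here, no comparable step exists among the measured compounds, so the direction rests on compound 3 alone. Because compound 3 gives 152%, compound 4 is expected to remain a strong agonist, with an estimated moderate downward step a number 32 percentage points lower from compound 3 to compound 4 (beyond the scatter). For compound 4 the expected value is 120%, with a range from 70% to 160%.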

Compound 4, largest response reached (reported as percent of maximum), in percent of the reference or control that the assay uses: 136%
Beside the measured number, compound 4's estimate is 16 percentage points below it, and the stated range covers the measured number.
By their numbers in this assay, from the lowest: compounds 2 and 1 (each within the scatter of the next); then compound 4; then compound 3.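

In this assay, for the compounds shown here, fluoro in place of chloro on this aromatic carbon, next to the ring nitrogen, gives a number 16 percentage points lower from compound 3 to compound 4 (beyond the scatter) and is the first single-place change seen at this position. The change costs only a modest part of the response, and compound 4 still reaches 136% as a strong agonist. No evidence is available to explain this step.

On these data alone, it remains open whether a nitrile or an amine on this same carbon would keep so large a response. As far as these compounds go, how the unsubstituted carbon would compare also remains open.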